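A few compounds are considered here, and "the series" means these few. Any claim that something is new, unique, unknown or untested is made for them only; others in the source may bear on it.

Of the compounds shown here, two have so far been measured in an assay on isolated protein for antagonist activity at Bile acid receptor (Homo sapiens), read by TR-FRET, with a stated time of 20 min, tested at 164 nM; a lower number here means less inhibition, a higher number more inhibition at the concentration tested (going by the name of the read-out). Compound 1 `O=C(Nc1ccc(S(=O)(=O)N2CCOCC2)cc1)c1cn(-c2ccccc2)nc1-c1ccc(F)cc1` gives 21.2%. Compound 2 `Cc1ccc(-c2nn(-c3cccc(Cl)c3)cc2C(=O)Nc2ccc(C)c(S(=O)(=O)N3CCOCC3)c2)cc1` gives 99.3%, the higher of the two numbers, and it lies above compound 1 by an amount beyond the usual scatter of repeated measurements. Compound 3 `Cc1ccc(-c2nn(-c3ccc(Cl)cc3Cl)cc2C(=O)Nc2ccc(C)c(S(=O)(=O)N3CCOCC3)c2)cc1` has not yet been measured. It differs from compound 2 in one place: 2,4-dichlorophenyl in place of 3-chlorophenyl on an aromatic nitrogen. For the measured compounds named here, no pair of measured compounds here shows what putting 2,4-dichlorophenyl in place of 3-chlorophenyl on an aromatic nitrogen does, so the data give no direct guide to the size of this step. Because compound 2 already gives 99.3%, a number near the top of the scale of this read-out, there is little room for a rise. The step is expected to be small, a number 4.3 percentage points lower from compound 2 to compound 3 (within the scatter), within the scatter or slightly downward. Compound 3 is therefore estimated at about 95%, with a likely range from 75% to 100%.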

Compound 3, a percentage reported as inhibition, at one concentration (the size of the read-out at that concentration, not a potency): 120%
Compound 3: the middle estimate sits 25 percentage points below what was measured, outside the stated range (above it).
By their numbers in this assay, from the lowest: compound 1; then compound 2; then compound 3.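

Putting 2,4-dichlorophenyl in place of 3-chlorophenyl on the aromatic nitrogen gives a number 20.7 percentage points higher from compound 2 to compound 3 (beyond the scatter) in this assay and so shows that this position still responds to change, even starting from a compound as high as compound 2. The number given by compound 2 was therefore no ceiling for this read-out, and the extra chlorine on this ring goes with a real rise. Nothing available here explains the rise.

The compounds shown leave open whether 2-chlorophenyl or 4-chlorophenyl alone would match the effect of 2,4-dichlorophenyl, and what a 4-methoxyphenyl group would do at the same place. They also leave open whether the same step would hold on a different core, such as that of compound 1.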